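The compounds below may be only part of what the source reports. "The series", "measured", "known", "first", "only" and "open" are said of these compounds alone.

Measured so far:
- compound 1 `COc1cc(/C(C)=N/Nc2nc3ccccc3nc2Cc2ccccc2)cc(OC)c1OC`: 29 nM
- compound 2 `Clc1ccc(/C=N/Nc2nc3ccccc3nc2Cc2ccccc2)cc1`: 76 nM

Both compounds were tested in an assay on isolated protein for inhibition of Amine oxidase [flavin-containing] A (Homo sapiens), read by spectrophotometry; a higher number here means a weaker inhibitor, a lower number a stronger inhibitor. Compound 1 gives 29 nM, and compound 2 gives 76 nM. Compound 2 thus has the higher of the two numbers, which makes it the weaker inhibitor of the pair, and the gap between it and compound 1 lies beyond the usual scatter of this assay. Among the measured compounds shown here, no measured pair differs in just one place, so no single structural change has yet been tied to a change in the numbers.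

Compound 3 `C/C(=N\Nc1nc2ccccc2nc1Cc1ccccc1)c1ccccn1` has not been measured in this assay yet. Relative to compound 2 it carries a group of 9 heavy atoms (7 carbon, 2 nitrogen; one six-membered aromatic ring with 1 hetero atom) in place of a group of 9 heavy atoms (7 carbon, 1 nitrogen, 1 chlorine; one six-membered aromatic ring of carbon only), on a nitrogen on an aromatic ring. For the measured compounds named here, nothing among the measured compounds tells how this particular exchange affects the numbers; only the two values themselves are known. Going by the values given here, the step from compound 2 to compound 3 is therefore expected to be modest, a 1.5-fold lower number from compound 2 to compound 3 (0.18 log units; within the scatter), leaning towards a somewhat stronger inhibitor, since compound 1, the only other compound measured, also carries a methyl on the double bond outside the rings and gives 29 nM. Compound 3 is accordingly expected to give about 50 nM in this assay, with a plausible range from 15 nM to 200 nM.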

Compound 3, half-maximal inhibitory concentration: 91 nM
Estimate against measurement, compound 3: 1.8-fold (0.26 log units) below; low and high end bracket the measured number.
By their numbers in this assay, from the lowest: compound 1; then compounds 2 and 3 (each within the scatter of the next).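

In this assay, among the compounds shown here, this is the first exchange that can be read at this place, on a nitrogen on an aromatic ring, and it gives a 1.2-fold higher number from compound 2 to compound 3 (0.08 log units; within the scatter). A group built on a six-membered aromatic ring with 1 hetero atom, and without chlorine, can therefore stand in for the group built on a six-membered aromatic ring of carbon only, and the measurement cannot tell the two apart. The second hydrogen-bond acceptor counted in the entering group likewise comes with no readable shift in the number, and no measurement at hand offers an explanation for this, so it remains an observation only.

From the compounds shown here alone, the exchange alters several features at once: the chlorine leaves, a ring nitrogen enters and a methyl appears on the double bond, so the part played by each stays unknown, and their separate contributions could even cancel out. The compounds shown also leave open whether a group of another kind at this place, such as a ring carrying an amine or a carboxylic acid, or a longer chain on the double bond, would keep the number at this level or move it.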